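The compounds below may be only part of what the source reports. "The series", "measured", "known", "first", "only" and "open" are said of these compounds alone.

Measured in a toxicity assay on CHO cells (Cricetulus griseus) for cytotoxicity, read by WST assay, with a stated time of 24 h; on this read-out higher numbers stand for weaker inhibition and lower numbers for stronger inhibition:
Compound 1 `CC(C)=CCCC(C)=CCNCCCN`: > 150000 nM (a limit)
Compound 2 `CC(C)=CCCC(C)=CCNCCCN1CCCC1=O`: > 150000 nM (a limit)
Compound 3 `CC(C)=CCC/C(C)=C\CCC(C)=CCNCCCN`: 32100 nM

Of these three, only compound 3 gives an actual number, 32100 nM. Compound 4 `CC(C)=CCC/C(C)=C\CCC(C)=CCNCCCCCN` differs from it in one place: 2-aminoethyl in place of amino on a saturated chain carbon, three bonds along the chain from an amine nitrogen. The same place changes in a step that the two limits leave unreadable from compound 1 to compound 2, but that step gives no size. A different change, an at least 4.6-fold lower number from compound 1 to compound 3 (0.66 log units; beyond the scatter), shows that numbers in this assay can move among these compounds, yet it lies elsewhere in the structure. Neither step sizes the present change, so no shift beyond the scatter is expected, with some room towards a lower number. The expected step is a 1.3-fold lower number from compound 3 to compound 4 (0.11 log units; within the scatter). Compound 4 is estimated at 25000 nM, with an expected range of 10000 nM to 60000 nM.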

Compound 4, half-maximal inhibitory concentration: 38400 nM
Compound 4: the middle estimate sits 1.5-fold (0.19 log units) below what was measured; measured number inside the range.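

At this place, on a saturated chain carbon, three bonds along the chain from an amine nitrogen, this assay now gives a readable size for 2-aminoethyl in place of amino: a 1.2-fold higher number from compound 3 to compound 4 (0.08 log units; within the scatter). The two compounds thus lie within the scatter of each other. The earlier step at this place, to 2-oxopyrrolidin-1-yl, cannot be read, because both its values are limits: the limit of > 150000 nM in this assay, at which 2 of the 4 values shown sit.

Going by these compounds, whether a longer chain such as 3-aminopropyl, or a carboxylic acid in place of the terminal amine, would give a similar number stays open. So does whether 2-aminoethyl would give a similar result on the shorter chain of compound 1.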